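The compounds below may be only part of what the source reports. "The series", "measured", "known", "first", "only" and "open" are said of these compounds alone.

Compound 2 `O=C1CCCCC1C1CC(=O)N(c2ccccc2)C1=O` gives 78300 nM in an assay on cells (1-87 tumor cell line) for inhibition of Polyunsaturated fatty acid 5-lipoxygenase (Homo sapiens), with a stated time of 5 min (on this read-out lower numbers stand for stronger inhibition and higher numbers for weaker inhibition), which places it second highest of the three numbers measured there. Compound 3 `O=C1CCCC1C1CC(=O)N(c2ccccc2)C1=O`, the nearest to it, gives 98600 nM in this assay, a gap within the scatter, while compound 1 `NS(=O)(=O)c1ccc(N2C(=O)CC(C3CCCCC3=O)C2=O)cc1`, the furthest, gives 21300 nM in this assay.

Compound 4 `O=C1CCCCC1C1CC(=O)N(c2ccc(Br)cc2)C1=O` differs from compound 2 by bromo in place of hydrogen on an aromatic carbon, the group sitting para to a large group on the ring attached to the shared core of compound 2. Going by the values given here, the one measured step at that place of the ring is a 3.7-fold higher number from compound 1 to compound 2 (0.57 log units; beyond the scatter), where the group entering was sulfamoyl rather than bromo. Among the compounds with values here, no measured pair shows bromo against hydrogen, so the bearing of that step on the present change is indirect. Given that the only change seen at that place moved the number by that amount, compound 4 is expected to show a step of a 1.7-fold lower number from compound 2 to compound 4 (0.24 log units; within the scatter) in this assay, that is, a modestly lower number than compound 2. Compound 4 is therefore estimated at 45000 nM in this assay, with a range from 15000 nM to 150000 nM.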

Compound 4, half-maximal inhibitory concentration: 131000 nM
Estimate against measurement, compound 4: 2.9-fold (0.46 log units) below, within the range that was stated.
By their numbers in this assay, from the lowest: compound 1; then compounds 2, 3 and 4 (each within the scatter of the next).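

In this assay the change from hydrogen to bromo gives a 1.7-fold higher number from compound 2 to compound 4 (0.22 log units; within the scatter) and so does not separate the two groups at this place on the ring. Sulfamoyl does stand apart from bromo, with a 6.2-fold higher number from compound 1 to compound 4 (0.79 log units; beyond the scatter) on the same core, so it now differs beyond the scatter from both other groups seen here. Of these three groups only sulfamoyl gives a distinct number, and nothing available on these compounds accounts for that.

Going by these compounds, whether an amine, a carboxylic acid or a methoxy group at this place would group with sulfamoyl or with hydrogen and bromo remains open. On these data alone, it is also open whether sulfamoyl would give a similar step on the core of compound 3, or whether bromo would read the same at another place on the ring.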